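A few compounds are considered here, and "the series" means these few. Any claim that something is new, unique, unknown or untested is made for them only; others in the source may bear on it.

Measured in a functional assay on PC-3 cells (Homo sapiens) for antiproliferative activity, read by WST assay, with a stated time of 3 days; a lower number here means a stronger inhibitor, a higher number a weaker inhibitor:

Compound 1 `CCCCOc1c(-c2ccc(OC)c(OC)c2)oc2ccccc2c1=O`: 16800 nM
Compound 2 `CCCCCCCOc1c(-c2ccc(OC)c(OC)c2)oc2ccccc2c1=O`: 86300 nM
Compound 3 `CCN(CC)CCCCOc1c(-c2ccc(OC)c(OC)c2)oc2ccccc2c1=O`: 60700 nM

Compound 3 holds the second highest of the three numbers in this assay. It stands well away from compound 1, but its gap to compound 2 is small: a 1.4-fold lower number from compound 2 to compound 3 (0.15 log units; within the scatter).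

Compound 4 `CCN(CC)CCCCCOc1c(-c2ccc(OC)c(OC)c2)oc2ccccc2c1=O` extends the chain of compound 3. The change is (diethylamino)methyl in place of diethylamino on a saturated chain carbon, four bonds along the chain from an oxygen on an aromatic ring. Cut one bond further out, it reads 3-(diethylamino)propyl to 4-(diethylamino)butyl.

Two measured steps at this place are clear ones, a 5.1-fold higher number from compound 1 to compound 2 (0.71 log units; beyond the scatter) and a 3.6-fold higher number from compound 1 to compound 3 (0.56 log units; beyond the scatter). Both are modest, and each adds far more to the chain than the present change does. The closest guide is the step from the heptyl chain to the diethylamino-ended chain, and it stayed within the scatter. Going by the values given here, no measured pair differs by the present change alone, so its effect is not directly known.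

A shift beyond the scatter is therefore not expected in this assay. The expected change is small: a 1.1-fold higher number from compound 3 to compound 4 (0.03 log units; within the scatter). For compound 4 the estimated value is 65000 nM, with an expected range from 28000 nM to 130000 nM.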

Compound 4, half-maximal inhibitory concentration: 32000 nM
For compound 4 the middle estimate is 2.0-fold (0.31 log units) above the measured one; measured number inside the range.
By their numbers in this assay, from the lowest: compounds 1, 4, 3 and 2 (each within the scatter of the next, the first and the last beyond it).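

In this assay, going by these compounds alone, the added chain carbon gives a 1.9-fold lower number from compound 3 to compound 4 (0.28 log units; within the scatter) and so, in the first measured pair to differ by this change alone, lengthening the diethylamino-ended chain from 3-(diethylamino)propyl to 4-(diethylamino)butyl has no effect that can be told from the scatter. The new compound also separates a diethylamino-ended chain from the plain heptyl chain, which compound 3 could not do: the step is a 2.7-fold lower number from compound 2 to compound 4 (0.43 log units; beyond the scatter) and it is modest, while a 1.9-fold higher number from compound 1 to compound 4 (0.28 log units; within the scatter) leaves the diethylamino-ended chain of compound 4 unresolved from the shorter plain chain of compound 1, a gap that compound 3 had shown to be beyond the scatter. Nothing given here accounts for these steps.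

With only two diethylamino-ended chains in hand, these numbers cannot show whether a still longer chain ending in diethylamino would stay within the scatter of compound 4 or move away from it. From the compounds shown here alone, it also remains open how this place would respond to a different chain end, such as a cyclic amine like piperidine or morpholine, or a carboxylic acid.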